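A Branching Methyl on Two Related Cores

The compounds below may be only part of what the source reports. "The series", "measured", "known", "first", "only" and "open" are said of these compounds alone.

Compound 1 `CCCOC(=O)C1=C(C)NC(=O)NC1c1cccs1` carries an ester chain on its core. In an assay on membranes from CHO cells for displacement of a labelled ligand from adenosine receptor A1 (Homo sapiens), read by scintillation counting, with a stated time of 60 min, tested at 1 uM (a lower number here means less inhibition, a higher number more inhibition at the concentration tested (going by the name of the read-out)), compound 1 gives 43%. Compound 2 `CC1=C(C(=O)OCC(C)C)C(c2cccs2)NC(=O)N1` differs from it only by methyl in place of hydrogen on a saturated chain carbon bound to two saturated chain carbons, and in this assay compound 2 gives 25%, a step of a number 18 percentage points lower from compound 1 to compound 2 (beyond the scatter). Compound 3 `CCCC(=O)C1=C(C)NC(=O)NC1c1ccco1` has a ketone chain on a different core; the difference between its core and the core of compound 1 is not broken down here. In this assay compound 3 gives 1%, the lowest of the three. Compound 4 `CC1=C(C(=O)CC(C)C)C(c2ccco2)NC(=O)N1` is unmeasured and differs from compound 3 by methyl in place of hydrogen on a saturated chain carbon bound to two saturated chain carbons, the same change as between compound 1 and compound 2, at the same place. Because compound 3 gives 1%, there is little room for a drop of the earlier size. The step from compound 3 to compound 4 is expected near a number 1 percentage points lower from compound 3 to compound 4 (within the scatter). Compound 4 is estimated at 0%, between -12% and 12%.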

Compound 4, a percentage reported as inhibition, at one concentration (the size of the read-out at that concentration, not a potency): 16%
Compound 4: the middle estimate sits 16 percentage points below what was measured; measured number outside the range, above it.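

On the second core the same methyl gives a number 15 percentage points higher from compound 3 to compound 4 (beyond the scatter) in this assay, whereas it lowered the number on the first core. Set side by side, the two steps differ: the same change on two cores in this assay, a number 18 percentage points lower (beyond the scatter) from compound 1 to compound 2 and a number 15 percentage points higher (beyond the scatter) from compound 3 to compound 4, 33 percentage points apart, beyond the scatter of two such steps. In this series, then, the result of adding this methyl on one core did not predict even the direction of the result on the other, although two pairs cannot show which difference between the cores lies behind this or how other cores would respond.

The compounds shown leave open how a longer chain or an amine at the end of the chain would read on either core. They also leave open whether this methyl would raise or lower the number on a third core.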